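Nitrophenyl piperazine variant of the chloro-oxindole thiosemicarbazone

This account rests on a few compounds, and the source may have more. Where it says the series, first, only, none or still open, it means among the compounds named here.

Working notes on a small set of thiosemicarbazones built on a chlorinated oxindole core. Two members have been measured in a functional assay on A549 cells (Homo sapiens) for inhibition, read by MTT assay, with a stated time of 72 h; a lower number here means a stronger inhibitor, a higher number a weaker inhibitor. Compound 1 `O=C1Nc2cccc(Cl)c2/C1=N/NC(=S)N1CCN(c2ccccc2)CC1` gives 55900 nM in this assay. Compound 2 `Cc1ccc(N2CCN(C(=S)N/N=C3\C(=O)Nc4ccc(Cl)cc43)CC2)c(C)c1` gives 3590 nM in this assay, the lowest of the two numbers recorded; the value of compound 1 stands well beyond the scatter above it. Compound 1 and compound 2 differ in more than one place, so nothing is attributed to any single change between them.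

Compound 3 `O=C1Nc2ccc(Cl)cc2/C1=N/NC(=S)N1CCN(c2ccc([N+](=O)[O-])cc2)CC1` is the next member to be measured in this assay. It differs from compound 2 by 4-nitrophenyl in place of 2,4-dimethylphenyl on an amine nitrogen in a ring. Among the compounds with values here, no measured pair in this set isolates a change on the ring nitrogen that bears the aryl group, so the size and direction of the step from compound 2 are not anchored by data. The expectation is a step of modest size, a 1.7-fold higher number from compound 2 to compound 3 (0.22 log units; within the scatter), leaning toward a weaker inhibitor but possibly within the scatter. Compound 3 is therefore estimated at 6000 nM in this assay, with a range from 1500 nM to 25000 nM.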

Compound 3, half-maximal inhibitory concentration: 11800 nM
For compound 3 the middle estimate is 2.0-fold (0.29 log units) below the measured one, and the stated range covers the measured number.
By their numbers in this assay, from the lowest: compound 2; then compound 3; then compound 1.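

Compound 3 gives the series its first reading of a single change on an amine nitrogen in a ring: in this assay, 4-nitrophenyl in place of 2,4-dimethylphenyl gives a 3.3-fold higher number from compound 2 to compound 3 (0.52 log units; beyond the scatter). The position is therefore not indifferent to the aryl group it carries, since this step lies beyond the scatter even though both groups contain one six-membered aromatic ring of carbon only. Nothing available here bears on what lies behind the step.

Within the data shown here, with only one step at this position, the separate contributions of removing the two methyl groups and adding the nitro group remain unresolved, and no trend across aryl groups can be drawn. A 4-aminophenyl or 4-carboxyphenyl group on the same nitrogen, or a 4-methylphenyl group carrying one of the two methyl groups alone, would help show whether the step follows the nitro group itself or the loss of the methyl groups.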